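The compounds below may be only part of what the source reports. "The series", "measured", "known", "first", "only" and "open" are said of these compounds alone.

Measured compounds:
Compound 1 `C=CC(=O)Nc1cccc2c1cc(C)n2-c1nc2c(c(NCc3cccc(O)c3)n1)CCC2` — 1200 nM
Compound 2 `Cc1cc2c(C(N)=O)cccc2n1-c1nc2c(c(NCc3cccc(O)c3)n1)CCC2` — 400 nM

In a functional assay on HCT-116 cells (Homo sapiens) for inhibition, read by luminescence and CellTiter-Glo, with a stated time of 72 h (on this read-out higher numbers stand for weaker inhibition and lower numbers for stronger inhibition), compound 2 gives 400 nM, the lowest of the two numbers recorded so far. Within the data shown here, its nearest neighbour is compound 1, which gives 1200 nM, and the one measured step is a 3.0-fold lower number from compound 1 to compound 2 (0.48 log units; beyond the scatter). That step swapped the whole group on an aromatic carbon of the shared core, exchanging (vinylcarbonyl)amino for carbamoyl.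

Compound 3 `CCONC(=O)c1cccc2c1cc(C)n2-c1nc2c(c(NCc3cccc(O)c3)n1)CCC2` keeps the carbamoyl of compound 2 and alters it at its outer end: ethoxy in place of hydrogen on an amide-type nitrogen. Among the measured compounds shown here, no measured step touches the amide nitrogen itself, so the single step available bears on this change only indirectly, by showing that this position tolerates a change of group without a large swing in this assay. For the measured compounds named here, with that as the only guide, a step of modest size at most is expected, more likely towards a somewhat higher number, though a result within the scatter would not surprise. Compound 3 is therefore estimated at 600 nM in this assay, between 200 nM and 2000 nM, which would mean a 1.5-fold higher number from compound 2 to compound 3 (0.18 log units; within the scatter).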

Compound 3, half-maximal inhibitory concentration: 600 nM
Compound 3: the middle estimate sits on the measured number at the digits printed, and the stated range covers the measured number.
By their numbers in this assay, from the lowest: compounds 2, 3 and 1 (each within the scatter of the next, the first and the last beyond it).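

In this assay, among these compounds, ethoxy in place of hydrogen on the amide-type nitrogen gives a 1.5-fold higher number from compound 2 to compound 3 (0.18 log units; within the scatter) and so shows that this nitrogen, untouched in the earlier compounds, can carry ethoxy with no difference that stands out from the scatter. Ethoxycarbamoyl in place of (vinylcarbonyl)amino on the aromatic carbon gives a 2.0-fold lower number from compound 1 to compound 3 (0.30 log units; within the scatter) and so places compound 3 within the scatter of both compound 1 and compound 2, although the step between those two lies beyond it. Nothing available offers an explanation for this result.

The compounds shown carry only hydrogen or ethoxy on this nitrogen, so it remains open what a smaller group such as methoxy, a longer chain such as butoxy, or a ring such as benzyloxy would give there. Going by these compounds, it also remains open how a carboxylic acid or an amine in place of the whole carbamoyl on the aromatic carbon would compare with these three compounds.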